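Vero Cytotoxicity Held at the Limit Across Four Analogues

The source may hold more compounds than are shown below. What is called first, only, known or untested is meant among the compounds shown, and "the series" means these compounds.

compound 1 `O=[N+]([O-])c1cn2c(n1)OCC(COc1ccc(-c3ccc(C(F)(F)F)cc3)cc1)C2` — > 128000 nM
compound 2 `O=[N+]([O-])c1cn2c(n1)OCC(COc1ccc(-c3ccc(F)cc3)cc1)C2` — > 128000 nM
compound 3 `O=[N+]([O-])c1cn2c(n1)OCC(COc1ccc(-c3ccc(C(F)(F)F)cc3)cn1)C2` — > 128000 nM

In an ADME assay on Vero cells (Chlorocebus sabaeus) for cytotoxicity, with a stated time of 72 h (on this read-out lower numbers stand for stronger inhibition and higher numbers for weaker inhibition), compound 1 reaches only the limit > 128000 nM. Compound 2 likewise gives only the limit > 128000 nM. Compound 3 too shows only the limit > 128000 nM, so all three sit at the limit of > 128000 nM in this assay, at which 3 of the 3 values shown sit. The change from compound 1 to compound 2 is fluoro in place of trifluoromethyl on an aromatic carbon, and the step that the two limits leave unreadable from compound 1 to compound 2 is left unreadable by the two limits. How the core of compound 3 differs from that of compound 1 is not broken down here. Compound 4 `O=[N+]([O-])c1cn2c(n1)OCC(COc1ccc(-c3ccc(F)cc3)cn1)C2` differs from compound 3 by fluoro in place of trifluoromethyl on an aromatic carbon, the same change as that from compound 1 to compound 2. Since compound 3 shows only the limit > 128000 nM and compound 2 also shows only a limit, the step that the limit leaves unreadable from compound 3 to compound 4 is expected to be small, with compound 4 again expected to sit at the limit. Compound 4 is therefore estimated at 200000 nM in this assay.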

Compound 4, half-maximal inhibitory concentration: > 128000 nM
Compound 4: no number, only a limit; the forecaster's own chance of this, stated with the estimate: 85%; the middle value lies beyond the limit too.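

No step can be read from compound 3 to compound 4, as both give only a limit in this assay: the limit of > 128000 nM in this assay, at which 4 of the 4 values shown sit. The compounds shown leave open what actual value any of the four would have, and whether any of these structural differences changes it.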